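This account rests on a few compounds, and the source may have more. Where it says the series, first, only, none or still open, it means among the compounds named here.

Among the compounds with values here, compound 1 `CNC(=O)c1cc(C(=O)N[C@H]2CC[C@H](O)CC2)c([C@@H](C)c2cccc(C)c2)o1` is one of three compounds measured in a physicochemical assay for lipophilicity; on this read-out lower numbers stand for lower lipophilicity and higher numbers for higher lipophilicity. In this assay compound 1 gives 3.3, the second highest of the three numbers. Compound 3 `CNC(=O)c1cc(C(=O)N[C@H]2[C@@H]3COC[C@@H]32)cc2c1O[C@H](CF)[C@H]2c1ccccc1` gives 3.6, which lies within the usual scatter of the number for compound 1, so the two cannot be told apart. Compound 2 `CC(=O)Nc1c(F)cc(C(=O)N[C@H]2CC[C@H](O)CC2)cc1O[C@@H](C)c1ccccc1` gives 2.8, a lower number beyond that scatter. Compound 4 `CNC(=O)c1cc(C(=O)N[C@H]2CC[C@H](O)CC2)c([C@@H](C)c2ccc(C)cc2)o1` has not yet been measured. It differs from compound 1 in one place: 4-methylphenyl in place of 3-methylphenyl on a saturated chain carbon bound to an aromatic carbon and a saturated chain carbon. The two have the same atoms, joined differently. Because compound 1 gives 3.3 and the change moves only a methyl group around the same ring, no step beyond the scatter is expected, no change at the digits printed from compound 1 to compound 4 (within the scatter). Compound 4 is therefore estimated at 3.3, within a range of 3 to 3.6.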

Compound 4, distribution coefficient: 3.4
Compound 4: the middle estimate sits 0.10 log units below what was measured; low and high end bracket the measured number.
By their numbers in this assay, from the lowest: compound 2; then compounds 1, 4 and 3 (each within the scatter of the next).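

Compound 1 and compound 4 are the first pair shown that differ in one place, and this assay gives a number 0.10 log units higher from compound 1 to compound 4 (within the scatter) for this swap of 3-methylphenyl to 4-methylphenyl. On this read-out, moving the methyl group around the ring at this position therefore leaves the two compounds indistinguishable. No measurement shown explains why they read alike. Still open, from the compounds shown here alone, is whether a group carrying an amine or a carboxylic acid in place of the 4-methylphenyl would give a step beyond the scatter. Going by these compounds, whether the same swap would read alike on another core is also open.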